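Cutting the basic side chain down to a propargyl amide

The source may hold more compounds than are shown below. What is called first, only, known or untested is meant among the compounds shown, and "the series" means these compounds.

In an assay on HL-60 cells for agonist activity at vitamin D3 receptor (Homo sapiens), read by microscopy, with a stated time of 96 h (a higher number here means that more compound is needed for the effect, a lower number that less compound is needed), compound 3 `CCN(CC)CCCNC(=O)c1ccc(C(CC)(CC)c2ccc(OCC(O)C(C)(C)C)c(C)c2)n1CC` gives 66 nM, the second highest of the three numbers available. Compound 1 `CCOC(=O)CN(C)C(=O)c1ccc(C(CC)(CC)c2ccc(OCC(O)C(C)(C)C)c(C)c2)n1CC` gives 210 nM and compound 2 `CCn1c(C(=O)NCCN(C)C)ccc1C(CC)(CC)c1ccc(OCC(O)C(C)(C)C)c(C)c1` gives 14 nM. Compound 4 `C#CCNC(=O)c1ccc(C(CC)(CC)c2ccc(OCC(O)C(C)(C)C)c(C)c2)n1CC` differs from compound 3 by ethynyl in place of 2-(diethylamino)ethyl on a saturated chain carbon bound to an amide-type nitrogen. The comparisons that bear on this are a 15-fold lower number from compound 1 to compound 2 (1.18 log units; beyond the scatter), a 3.2-fold lower number from compound 1 to compound 3 (0.50 log units; beyond the scatter) and a 4.7-fold higher number from compound 2 to compound 3 (0.67 log units; beyond the scatter); in this small set the two compounds carrying an amine-bearing chain give lower numbers than compound 1, which carries none. Compound 4 likewise carries no such chain. A modest rise is therefore expected for compound 4, a 2.4-fold higher number from compound 3 to compound 4 (0.38 log units; beyond the scatter). Compound 4 is estimated at 160 nM, with a range from 50 nM to 500 nM.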

Compound 4, half-maximal effective concentration: 240 nM
The estimate for compound 4 lay 1.5-fold (0.18 log units) below the measured number, and the stated range covers the measured number.
By their numbers in this assay, from the lowest: compound 2; then compound 3; then compounds 1 and 4 (each within the scatter of the next).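

In this assay, ethynyl in place of 2-(diethylamino)ethyl gives a 3.6-fold higher number from compound 3 to compound 4 (0.56 log units; beyond the scatter), and ethynyl in place of (dimethylamino)methyl gives a 17-fold higher number from compound 2 to compound 4 (1.23 log units; beyond the scatter), so at this position both amine-bearing chains give lower numbers than propargyl. Propargylamino and the ester-bearing amino group of compound 1 cannot be told apart, at a 1.1-fold higher number from compound 1 to compound 4 (0.06 log units; within the scatter), so two quite different amine-free groups read alike here. No measurement at hand explains these steps. From the compounds shown here alone, whether the amine nitrogen itself or simply a longer chain matters remains open, since a plain butyl chain or a morpholine-bearing chain could separate the two.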